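This account rests on a few compounds, and the source may have more. Where it says the series, first, only, none or still open, it means among the compounds named here.

Working notes on the series.

Of the compounds shown here, two have numbers so far. Compound 1 `CC(C)c1n[nH]c2c(NCc3ccc(-c4ccccn4)cc3)nc(SCC(N)CN)nc12` gives 480 nM in a functional assay on HT cells (Homo sapiens) for antiproliferative activity, read by fluorescence, with a stated time of 72 h; on this read-out lower numbers stand for stronger inhibition of growth and higher numbers for weaker inhibition of growth. Going by the values given here, compound 2 `CC(C)c1n[nH]c2c(NCc3ccc(-c4ccccn4)cc3)nc(SCCN)nc12` gives 22 nM in this assay and so stands lowest of the two numbers; the one step measured, a 22-fold lower number from compound 1 to compound 2 (1.34 log units; beyond the scatter), is a large one.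

Compound 3 `CC(C)c1n[nH]c2c(NCc3ccc(-c4ccccn4)cc3)nc(SC3CCCCC3O)nc12` is not yet measured. It differs from compound 2 at the sulfur: 2-hydroxycyclohexyl in place of 2-aminoethyl on a sulfur.

Among the compounds with values here, only one measured step exists, from compound 1 to compound 2, and it shows that a change on the chain carried by the sulfur can move the number far. It does not probe the present change, in which the 2-aminoethyl leaves entirely and a 2-hydroxycyclohexyl enters, so it gives direction only weakly. With the amine nitrogen gone, the number for compound 3 is expected to rise rather than fall, with wide uncertainty, an expected step of a 6.8-fold higher number from compound 2 to compound 3 (0.83 log units; beyond the scatter). The estimate for compound 3 in this assay is 150 nM, within a range of 25 nM to 1500 nM.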

Compound 3, concentration for 50% growth inhibition: 636 nM
Beside the measured number, compound 3's estimate is 4.2-fold (0.63 log units) below it, within the range that was stated.
By their numbers in this assay, from the lowest: compound 2; then compounds 1 and 3 (each within the scatter of the next).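

In this assay, 2-hydroxycyclohexyl in place of 2-aminoethyl on the sulfur gives a 29-fold higher number from compound 2 to compound 3 (1.46 log units; beyond the scatter) and is a large step, so this position responds strongly to an exchange of the whole group as well as to the added aminomethyl seen earlier. Set against 2,3-diaminopropyl, the same 2-hydroxycyclohexyl gives a 1.3-fold higher number from compound 1 to compound 3 (0.12 log units; within the scatter) and the two cannot be told apart on this read-out, although the two groups differ in ring content and in carrying oxygen or nitrogen; among the three compounds, only compound 2 with its 2-aminoethyl stands apart from the others by more than the scatter. No measurement on hand speaks to what lies behind these steps.

The exchange from compound 2 to compound 3 removes the amine nitrogen, brings in the hydroxyl and adds the six-membered ring all at once, so the compounds shown do not separate the share of each. On these data alone, a 2-hydroxyethyl group, a 2-aminocyclohexyl group or a longer chain such as 3-aminopropyl on the sulfur would take these changes apart, and how any of them would read remains open.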